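A few compounds are considered here, and "the series" means these few. Any claim that something is new, unique, unknown or untested is made for them only; others in the source may bear on it.

Compound 1 `O=S(=O)(NCCCNCc1ccc(Cl)c(Cl)c1)c1cc(C(F)(F)F)cc(C(F)(F)F)c1` is the starting point of this step. In a functional assay on BE(2)-C cells (Homo sapiens) for inhibition, read by MTT assay, with a stated time of 72 h (on this read-out lower numbers stand for stronger inhibition of growth and higher numbers for weaker inhibition of growth), compound 1 gives 2900 nM. Two close relatives keep the same core and swap only the aryl group on the benzyl side: compound 2 `COc1ccc(CNCCCNS(=O)(=O)c2cc(C(F)(F)F)cc(C(F)(F)F)c2)cc1OC` gives 3600 nM, and compound 3 `COc1ccc(CNCCCNS(=O)(=O)c2cc(C(F)(F)F)cc(C(F)(F)F)c2)cc1` gives 2800 nM. Among these three numbers compound 1 stands second highest, yet all three lie within the scatter of one another: a 1.2-fold higher number from compound 1 to compound 2 (0.09 log units; within the scatter), a 1.0-fold lower number from compound 1 to compound 3 (0.02 log units; within the scatter), and a 1.3-fold lower number from compound 2 to compound 3 (0.11 log units; within the scatter).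

Compound 4 `O=S(=O)(NCCCNCc1cccc(Cl)c1)c1cc(C(F)(F)F)cc(C(F)(F)F)c1` differs from compound 1 in one place: hydrogen in place of chloro on an aromatic carbon. Among the compounds with values here, the steps that bear on this are those changing the same aryl group. Replacing the whole 3,4-dichlorophenyl gave only a 1.2-fold higher number from compound 1 to compound 2 (0.09 log units; within the scatter) and a 1.0-fold lower number from compound 1 to compound 3 (0.02 log units; within the scatter), and removing a methoxy from an aromatic carbon gave a 1.3-fold lower number from compound 2 to compound 3 (0.11 log units; within the scatter). Removing a single chloro is a smaller change than any of those, so no step beyond the scatter is expected, in either direction: a 1.0-fold higher number from compound 1 to compound 4 (0.01 log units; within the scatter). Compound 4 is therefore estimated at 3000 nM, with a range from 1500 nM to 6000 nM.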

Compound 4, concentration for 50% growth inhibition: 6900 nM
Beside the measured number, compound 4's estimate is 2.3-fold (0.36 log units) below it, and the stated range ends below it.
By their numbers in this assay, from the lowest: compounds 3, 1, 2 and 4 (each within the scatter of the next, the first and the last beyond it).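

In this assay, within the data shown here, this is the first change to the aryl group that clears the scatter: losing the chloro para to a large group gives (a 2.4-fold higher number from compound 1 to compound 4 (0.38 log units; beyond the scatter)). The 3-chlorophenyl group also separates from the 4-methoxyphenyl group (a 2.5-fold higher number from compound 3 to compound 4 (0.39 log units; beyond the scatter)), but not from the 3,4-dimethoxyphenyl group (a 1.9-fold higher number from compound 2 to compound 4 (0.28 log units; within the scatter)), so the aryl group is not fully indifferent, though the effect is modest and compounds 2 and 3 carry no chloro at all yet stay within the scatter of compound 1. Nothing available here explains why this single chloro matters.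

As far as these compounds go, whether a bromo or a methyl group on that same aromatic carbon would keep the number close to that of compound 1 remains open. So does whether the step would hold with a longer chain in the shared core.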